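This account rests on a few compounds, and the source may have more. Where it says the series, first, only, none or still open, it means among the compounds named here.

Measured so far, in an assay for binding affinity to 17-beta-hydroxysteroid dehydrogenase type 2 (Homo sapiens), with a stated time of 20 min, tested at 1 uM; on this read-out higher numbers stand for more inhibition at the one concentration tested (going by the name of the read-out) and lower numbers for less inhibition:

Compound 1 `CC(=O)Nc1cccc(-c2ccc(CO)cc2)c1` gives < 10% in this assay; that value is a limit of the assay, not a number.
Compound 2 `CS(=O)(=O)Nc1ccc(-c2ccc(CO)cc2)cc1` gives < 10% in this assay; this too is a limit of the assay.
Compound 3 `CC(=O)Nc1cccc(-c2ccc(O)cc2)c1` gives < 10% in this assay; again a limit of the assay.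

Compound 1 and compound 3 differ in one place: hydroxy in place of hydroxymethyl on an aromatic carbon. The step that the two limits leave unreadable from compound 1 to compound 3 cannot be read, because the limit of < 10% in this assay, at which 3 of the 3 values shown sit, hides where each of the two values really lies. Compound 2 carries a different core from compound 1; how the two cores differ is not broken down here.

Compound 4 `CS(=O)(=O)Nc1ccc(-c2ccc(O)cc2)cc1` has not been measured. It differs from compound 2 by hydroxy in place of hydroxymethyl on an aromatic carbon, the same change that leads from compound 1 to compound 3. Since the earlier step left both ends at the limit, compound 4 is expected to stay near that limit, so the step that the limit leaves unreadable from compound 2 to compound 4 is estimated to be small. For compound 4 the expected value in this assay is therefore 7%, with a range from 0% to 20%.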

Compound 4, a percentage reported as inhibition, at one concentration (the size of the read-out at that concentration, not a potency): < 10%
Compound 4 gave a limit, no number (the forecaster's own chance of this, stated with the estimate: 70%); the middle value does not contradict the limit.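

The step between compound 2 and compound 4 cannot be read, because both results are limits of the assay and not numbers: the limit of < 10% in this assay, at which 4 of the 4 values shown sit.

The compounds shown leave open how much inhibition each one really gives, and whether putting hydroxy in place of hydroxymethyl makes any difference at all.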